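Isoindolinone acid series: chain length at the ring nitrogen

The compounds below may be only part of what the source reports. "The series", "measured", "known", "first", "only" and "open" are said of these compounds alone.

Measured compounds:
- compound 1 `O=C(O)CN1Cc2ccc(NC(=O)CCCC3CCNCC3)cc2C1=O`: 66000 nM
- compound 2 `O=C(O)CN1Cc2ccc(NC(=O)c3ccc(C4CCNCC4)cc3)cc2C1=O`: 24000 nM
- compound 3 `O=C(O)CN1Cc2ccc(NC(=O)c3ccc4c(c3)CNCC4)cc2C1=O`: 120000 nM

In a functional assay on a cell-free system (Platelet, plasma, Homo sapiens) for inhibition (on this read-out lower numbers stand for stronger inhibition and higher numbers for weaker inhibition), compound 1 gives 66000 nM, the second highest of the three numbers. Compound 3 gives 120000 nM, within the scatter of compound 1, so no order between them is claimed. Compound 2 gives 24000 nM, a lower number that lies beyond the scatter from compound 1.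

Compound 4 `O=C(O)CCN1Cc2ccc(NC(=O)CCCC3CCNCC3)cc2C1=O` differs from compound 1 by carboxymethyl in place of carboxy on a saturated chain carbon bound to an amide-type nitrogen in a ring. Among the compounds with values here, no measured pair shows this change, so the step of a 1.3-fold higher number from compound 1 to compound 4 (0.11 log units; within the scatter) is an expectation without a direct precedent; a step of modest size is expected, towards a somewhat higher number, with none beyond the scatter also plausible. For compound 4 the estimate in this assay is 85000 nM, between 25000 nM and 280000 nM.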

Compound 4, half-maximal inhibitory concentration: 5900 nM
The estimate for compound 4 lay 14-fold (1.16 log units) above the measured number, outside the stated range (below it).
By their numbers in this assay, from the lowest: compound 4; then compound 2; then compounds 1 and 3 (each within the scatter of the next).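

In this assay, carboxymethyl in place of carboxy on a saturated chain carbon bound to an amide-type nitrogen in a ring gives an 11-fold lower number from compound 1 to compound 4 (1.05 log units; beyond the scatter), a large step. Within the data shown here, the earlier compounds all carried the same acid chain, so this is the first reading of this position, and it shows that the position responds strongly to this small change. Nothing at hand accounts for the size of the step. Open, on these data alone, is whether a longer chain, such as 3-carboxypropyl, moves the number further, and whether the same change carries over to compound 2 or compound 3.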